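The compounds below may be only part of what the source reports. "The series", "measured", "known", "first", "only" and "open" are said of these compounds alone.

Measured compounds in a functional assay on HeLa cells (Homo sapiens) for inhibition, read by MTT assay, with a stated time of 72 h; a higher number here means a weaker inhibitor, a lower number a stronger inhibitor:
Compound 1 `Cc1nc(N(C)C(=O)NC(=O)c2c(F)cccc2F)sc1C(=O)N/N=C/c1ccccc1C(F)(F)F` gives 6.51 ug/mL.
Compound 2 `CN(C(=O)NC(=O)c1c(F)cccc1F)c1nc(C(F)(F)F)c(C(=O)N/N=C/c2ccccc2C(F)(F)F)s1` gives 19.6 ug/mL.
Compound 3 `CN(C(=O)NC(=O)c1c(F)cccc1F)c1nc(C(F)(F)F)c(C(=O)N/N=C/c2cccc(C(F)(F)F)c2)s1` gives 21.6 ug/mL.

Compound 2 stands second highest of the three numbers in this assay. Its nearest neighbour is compound 3, and the step between them, a 1.1-fold higher number from compound 2 to compound 3 (0.04 log units; within the scatter), is within the scatter, so the two cannot be ordered. Its furthest neighbour is compound 1, and the step of a 3.0-fold higher number from compound 1 to compound 2 (0.48 log units; beyond the scatter) is the only one in the set that lies beyond the scatter.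

Compound 4 `CN(C(=O)NC(=O)c1ccc(Cl)cc1Cl)c1nc(C(F)(F)F)c(C(=O)N/N=C/c2ccccc2C(F)(F)F)s1` differs from compound 2 in one place: 2,4-dichlorophenyl in place of 2,6-difluorophenyl on a carbonyl carbon. Neither measured step bears on this change. The step of a 3.0-fold higher number from compound 1 to compound 2 (0.48 log units; beyond the scatter) alters the substituent on the shared core, and the step of a 1.1-fold higher number from compound 2 to compound 3 (0.04 log units; within the scatter) moves the trifluoromethyl on the aryl group that sits on the carbon with a double bond to nitrogen; the ring on the carbonyl carbon is the same in compounds 1, 2 and 3. For the measured compounds named here, there is thus no measured precedent for exchanging 2,6-difluorophenyl for 2,4-dichlorophenyl at that position, and the expectation for compound 4 in this assay is a step of a 1.1-fold higher number from compound 2 to compound 4 (0.05 log units; within the scatter), that is none beyond the scatter, with a wide range to reflect the absence of any guiding step. Compound 4 is therefore estimated at 22 ug/mL, between 8 ug/mL and 60 ug/mL.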

Compound 4, half-maximal inhibitory concentration: 9 ug/mL
For compound 4 the middle estimate is 2.4-fold (0.39 log units) above the measured one, within the range that was stated.
By their numbers in this assay, from the lowest: compounds 1 and 4 (each within the scatter of the next); then compounds 2 and 3 (each within the scatter of the next).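

Until now the ring on the carbonyl carbon was the same in every compound, so nothing showed whether the number in this assay responds to a change there. With 2,4-dichlorophenyl in place of 2,6-difluorophenyl it does respond, with a 2.2-fold lower number from compound 2 to compound 4 (0.34 log units; beyond the scatter) as a modest shift towards a stronger inhibitor, while the trifluoromethyl on the shared core and the 2-(trifluoromethyl)phenyl on the carbon with a double bond to nitrogen stay as they are. This position therefore joins the substituent on the shared core, where a 3.0-fold higher number from compound 1 to compound 2 (0.48 log units; beyond the scatter) runs in the other direction, as a second place in the series where one change moves the number beyond the scatter. No measurement at hand accounts for the step.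

The identity of the halogen and its placing on the ring change together in this one step, so the compounds shown do not separate them, and a plain phenyl, a bromophenyl or a pyridine ring on the carbonyl carbon would extend the comparison. Also open, from the compounds shown here alone, is whether the step carries over to the methyl-bearing core of compound 1 or to the 3-(trifluoromethyl)phenyl of compound 3.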